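The source may hold more compounds than are shown below. What is called first, only, known or untested is meant among the compounds shown, and "the series" means these compounds.

Values in a functional assay on RS4-11 cells (Homo sapiens) for inhibition, read by CCK-8 assay, with a stated time of 48 h; on this read-out higher numbers stand for weaker inhibition and lower numbers for stronger inhibition:
- compound 1 `COc1ccc(NC(=O)NCCNS(=O)(=O)c2ccc(-c3ccccc3OCc3ccccc3)s2)cc1`: > 20000 nM (a limit)
- compound 2 `O=C(NCCNS(=O)(=O)c1ccc(-c2ccccc2Oc2ccc([N+](=O)[O-])c([N+](=O)[O-])c2)s1)Nc1cc(Cl)cc(Cl)c1`: 2100 nM
- compound 3 `COc1cccc(NC(=O)NCCNS(=O)(=O)c2ccc(-c3ccccc3OCc3ccccc3)s2)c1`: > 20000 nM (a limit)

Compound 3 gives > 20000 nM, which is a limit and not a number. That position is the limit of > 20000 nM in this assay, at which 2 of the 3 values shown sit. For the measured compounds named here, compound 2 gives the only true number so far, 2100 nM, but no single-place step links it to the other two compounds.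

Compound 4 `O=[N+]([O-])c1cccc(NC(=S)NCCNS(=O)(=O)c2ccc(-c3ccccc3OCc3ccccc3)s2)c1` is not yet measured. It keeps the core of compound 3, and the (3-methoxyphenyl)carbamoyl group leaves: a group of 12 heavy atoms (7 carbon, 2 nitrogen, 2 oxygen, 1 sulfur; one six-membered aromatic ring of carbon only) in place of a group of 11 heavy atoms (8 carbon, 1 nitrogen, 2 oxygen; one six-membered aromatic ring of carbon only), on an amine nitrogen.

Going by the values given here, the one measured step is a step that the two limits leave unreadable from compound 1 to compound 3. Among the compounds with values here, it gives no size to carry over, and no measured step covers a change of this kind. The expectation therefore rests first on compound 3, whose limit is > 20000 nM. Within the data shown here, compound 2 at 2100 nM shows only that a number can be read in this assay, and it differs from compound 4 in more than one place. A reading at the limit again is quite likely, and any number is expected to fall close to it. The expected move is an at least 1.2-fold lower number from compound 3 to compound 4 (0.09 log units; that floor lies within the scatter), small and uncertain in size. The estimate for compound 4 is 16000 nM, with an expected range from 5000 nM to 30000 nM.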

Compound 4, half-maximal inhibitory concentration: 11600 nM
Estimate against measurement, compound 4: 1.4-fold (0.14 log units) above, and the stated range covers the measured number.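

In this assay, for the compounds shown here, compound 4 gives 11600 nM, the first true number on the core shared with compound 1 and compound 3, so replacing the group on this amine nitrogen can give a readable number. Going by these compounds, the replacement gives an at least 1.7-fold lower number from compound 3 to compound 4 (0.23 log units; that floor lies within the scatter), and it gives an at least 1.7-fold lower number from compound 1 to compound 4 (0.23 log units; that floor lies within the scatter); both are floors only, and as each floor lies within the scatter, the true size of the change stays unknown. Compound 1 and compound 3 are limits and not numbers, and the same holds for the one earlier step between them, which cannot be read, so this position has only one measured point so far: the limit of > 20000 nM in this assay, at which 2 of the 4 values shown sit.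

The entering group brings in sulfur and a nitro group together, and no compound shown separates the two, so the urea carrying the nitro-substituted ring and the thiourea carrying the 3-methoxyphenyl group remain the open comparisons. Also open, on these data alone, is whether an amine or a carboxylic acid on the aromatic ring of the entering group would read beyond the scatter from compound 4 in this assay.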